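Rat microsomal stability: compound 2 and a diol analogue

The source may report more compounds than this note shows. Statements on the series, on what has been measured and on what is new or still open speak of the compounds shown alone.

Measured so far:
compound 2 `NC(=O)c1cnc2c(NC3CC3)cc(Nc3cccc(-c4ccc(C(F)(F)F)cc4F)c3)nn12` gives 86%
compound 1 `CNc1cc(Nc2cc(F)cc(F)c2OC)nn2c(C(=O)NC[C@](C)(O)CO)cnc12` gives 76%

Both values come from an ADME assay on microsomes from liver (Rattus norvegicus) for metabolic stability, read by mass spectrometry, with a stated time of 10 min, tested at 0.5 uM; a lower number here means that less of the compound is left, a higher number that more of the compound is left. Compound 2 stands highest of the two numbers, yet its nearest neighbour, compound 1, sits only slightly lower, a gap within the usual scatter, so the two are not told apart by this assay and no ordering between them is claimed. Going by the values given here, no single-change pair exists among the measured compounds, so no measured step is available for comparison.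

Compound 3 `C[C@](O)(CO)CNc1cc(Nc2cccc(-c3ccc(C(F)(F)F)cc3F)c2)nn2c(C(N)=O)cnc12` is not yet measured. It differs from compound 2 in one place: 2-hydroxy-2-(hydroxymethyl)propyl in place of cyclopropyl on a nitrogen on an aromatic ring. The entering group is the same one that compound 1 carries, though on a different nitrogen of the shared core, and compound 1 gives 76%, which is within the scatter of compound 2.

On that basis the step of a number 8 percentage points lower from compound 2 to compound 3 (within the scatter) is expected to be small, a slight drop at most, and most likely not beyond the scatter. For compound 3 the value in this assay is estimated at 78%, with a range from 62% to 92%.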

Compound 3, percent of the compound remaining: 75%
Beside the measured number, compound 3's estimate is 3 percentage points above it, and the stated range covers the measured number.
By their numbers in this assay, from the lowest: compounds 3, 1 and 2 (each within the scatter of the next, the first and the last beyond it).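

In this assay the series now has its first single-change reading at this position: 2-hydroxy-2-(hydroxymethyl)propyl in place of cyclopropyl on a nitrogen on an aromatic ring gives a number 11 percentage points lower from compound 2 to compound 3 (beyond the scatter) as a modest step. The position is therefore not indifferent to what it carries, since an open chain with a defined stereocentre, entering where a three-membered carbon ring leaves, changes the amount of compound remaining by more than repeat measurements would. Nothing at hand explains the step, and this single pair cannot assign it to any feature of the entering group.

As far as these compounds go, it remains open whether the step follows from losing the cyclopropyl ring or from gaining the hydroxyl groups of the chain, and an unsubstituted isobutyl chain or a cyclobutyl ring on the same nitrogen would help separate the two. Also unresolved is whether a shorter 2-hydroxyethyl chain, a chain ending in a primary amine, or the opposite stereoisomer of the diol chain would give a value closer to that of compound 2 or further from it.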